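This account rests on a few compounds, and the source may have more. Where it says the series, first, only, none or still open, it means among the compounds named here.

Of the compounds shown here, three have so far been tested in a functional assay on the whole organism (strain albino) for inhibition, with Rattus norvegicus as the target, read by paw edema, with stated times of 30 min and 3 h, at a dose of 0.28 mmol/kg by the oral route (a lower number here means less inhibition, a higher number more inhibition at the dose given (going by the name of the read-out)), a whole-animal measurement at a single oral dose. Compound 1 `CCn1c(SCC(=O)Nc2ccc(C(C)=O)cc2)nnc1-c1ccc(OC)c(OC)c1` gives 62%, compound 3 `CCn1c(SCC(=O)Nc2ccc(C(C)=O)cc2)nnc1-c1ccc(OC)cc1` gives 57%, and compound 2 `C=CCn1c(SCC(=O)Nc2ccc(/C(C)=N/O)cc2)nnc1-c1ccc(OC)c(OC)c1` gives 70%. Compound 2 stands highest of the three numbers, but its gap to compound 1 lies within the usual scatter, while only its gap to compound 3 lies beyond it. The difference between the cores of compound 1 and compound 2 is not broken down here. Compound 1 and compound 3 differ in one place only: hydrogen in place of methoxy on an aromatic carbon, and that change made a step of a number 5 percentage points lower from compound 1 to compound 3 (within the scatter). Compound 4 `C=CCn1c(SCC(=O)Nc2ccc(/C(C)=N/O)cc2)nnc1-c1ccc(OC)cc1` has not yet been measured. It stands to compound 2 exactly as compound 3 stands to compound 1, the same change at the same place: hydrogen in place of methoxy on an aromatic carbon. Because the earlier step was a number 5 percentage points lower from compound 1 to compound 3 (within the scatter), a step of similar size is expected from compound 2 to compound 4 in this assay, namely a number 5 percentage points lower from compound 2 to compound 4 (within the scatter). Compound 4 is thus expected to give about 65% in this assay, estimated to fall between 53% and 77%, resting on a single prior instance of this change.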

Compound 4, a percentage reported as inhibition, in the whole organism at one dose (the size of the read-out at that dose, not a potency): 63%
The estimate for compound 4 lay 2 percentage points above the measured number; measured number inside the range.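

Replacing methoxy with hydrogen, the change from 3,4-dimethoxyphenyl to 4-methoxyphenyl, gave in this assay a number 7 percentage points lower from compound 2 to compound 4 (within the scatter). Set beside the earlier step, the change carried over from one core to the other with no difference in size that can be told apart: the same change on two cores in this assay, a number 5 percentage points lower (within the scatter) from compound 1 to compound 3 and a number 7 percentage points lower (within the scatter) from compound 2 to compound 4, 2 percentage points apart, within the scatter of two such steps. This agreement does not show that the methoxy group has a real effect on the inhibition of paw edema, as each step taken alone lies within the scatter, and two cores are too few to establish a rule for the whole series.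

The compounds shown carry only methoxy or hydrogen at this place, so it remains open how a chlorine atom, a hydroxyl group or a longer alkoxy chain would behave there. Also open, on these data alone, is how much the ethyl and allyl groups on the one hand, and the ketone and oxime on the other, each contribute separately to the difference between the two cores.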